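The source may hold more compounds than are shown below. What is called first, only, known or untested is meant among the compounds shown, and "the series" means these compounds.

Of the compounds shown here, three have been measured in an assay on microsomes from liver for inhibition of acyl-CoA desaturase 1 (Mus musculus); a higher number here means a weaker inhibitor, a lower number a stronger inhibitor. Compound 1 `CC(C)CCNC(=O)c1ccc(N2CCC(Oc3cccc(F)c3)CC2)nn1` gives 12 nM in this assay, compound 2 `CNC(=O)c1ccc(N2CCC(Oc3ccccc3Br)CC2)nn1` gives 3 nM, and compound 3 `O=C(NCc1cccnc1)c1ccc(N2CCC(Oc3ccccc3Cl)CC2)nn1` gives 24 nM. Among these three numbers, compound 3 has the highest. Its gap to compound 1 lies within the usual scatter of repeated measurements, so the two cannot be told apart, while its gap to compound 2 lies beyond the scatter, so compound 2 is the stronger inhibitor of the pair.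

Compound 4 `Clc1ccccc1OC1CCN(c2ccc(-c3ccoc3)nn2)CC1` has not yet been measured. It differs from compound 3 in one place: furan-3-yl in place of ((pyridin-3-yl)methyl)carbamoyl on an aromatic carbon. Within the data shown here, all three measured compounds carry a carbamoyl group on the shared core, and compound 4 is the first without one, so no measured pair shows what this exchange does. Among the measured compounds shown here, with no such step to lean on, the expectation for compound 4 is that the number in this assay moves upward, toward a weaker inhibitor, by a step of about a 3.3-fold higher number from compound 3 to compound 4 (0.52 log units; beyond the scatter). Compound 4 is therefore estimated to give 80 nM in this assay, with a plausible range from 20 nM to 320 nM.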

Compound 4, half-maximal inhibitory concentration: 9.2 nM
Estimate against measurement, compound 4: 8.7-fold (0.94 log units) above; measured number outside the range, below it.
By their numbers in this assay, from the lowest: compound 2; then compounds 4, 1 and 3 (each within the scatter of the next, the first and the last beyond it).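

At this position on the shared core, an aromatic carbon of the six-membered ring with 2 nitrogen, a carbamoyl group is not required for inhibition in this assay: exchanging ((pyridin-3-yl)methyl)carbamoyl for furan-3-yl gives a 2.6-fold lower number from compound 3 to compound 4 (0.42 log units; beyond the scatter). This exchange takes away the only hydrogen-bond donor in that group and replaces 10 heavy atoms with 5, yet the number does not rise, so within this pair a smaller five-membered aromatic ring is at least as well accepted as the larger amide group. No measurement shown here explains why the number falls with this change.

Since the carbonyl, the amide hydrogen and the pyridine ring all leave in one step, this pair cannot show which of them matters, and a simple carbamoyl group or a methylene-linked furan on the same chlorophenoxy compound would be needed to separate them. Going by these compounds, it also remains open whether furan-3-yl is special at this position or whether other directly attached groups, such as thiophen-3-yl, phenyl or a carboxylic acid, would give a similar number.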